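Shifting the Piperidine Nitrogen onto the Chain

The compounds below may be only part of what the source reports. "The series", "measured", "known", "first", "only" and "open" are said of these compounds alone.

Measured compounds in an assay on isolated protein for binding affinity to Neuropeptide Y receptor type 1 (Homo sapiens); on this read-out higher numbers stand for weaker inhibition and lower numbers for stronger inhibition:
compound 1, `Clc1ccc(OCc2nc3ccccc3n2CCCC2CCCCN2)cc1`: 3230 nM
compound 2, `Clc1ccc(OCc2nc3ccccc3n2CCN2CCCCC2)cc1`: > 100000 nM
compound 3, `Clc1ccc(OCc2nc3ccccc3n2CCCC2CCCNC2)cc1`: 700 nM

The value for compound 2 is a limit of this assay, not a number (the limit of > 100000 nM in this assay, at which 1 of the 3 values shown sits). Compound 3 gives the lowest number of the two that were obtained, with compound 1 nearest a 4.6-fold lower number from compound 1 to compound 3 (0.66 log units; beyond the scatter). Compound 4, `Clc1ccc(OCc2nc3ccccc3n2CCCN2CCCCC2)cc1`, differs from compound 3 in one place: piperidin-1-yl in place of piperidin-3-yl on a saturated chain carbon, three bonds along the chain from an aromatic nitrogen. The step that bears most on this change runs the other way, an at least 140-fold lower number from compound 2 to compound 3 (2.15 log units; beyond the scatter), and an at least 30-fold higher number from compound 1 to compound 2 (1.49 log units; beyond the scatter) points the same way; both were large. Compound 4 is therefore expected to read higher, a 29-fold higher number from compound 3 to compound 4 (1.46 log units; beyond the scatter), and its value in this assay is estimated at 20000 nM (range 3000 nM to 100000 nM).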

Compound 4, inhibition constant: 7020 nM
For compound 4 the middle estimate is 2.8-fold (0.45 log units) above the measured one; low and high end bracket the measured number.
By their numbers in this assay, from the lowest: compound 3; then compound 1; then compound 4. At a limit, above all of these: compound 2.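

With the chain unchanged, in this assay piperidin-1-yl gives the higher number against both ring-carbon attachments, piperidin-3-yl (a 10-fold higher number from compound 3 to compound 4 (1.00 log units; beyond the scatter)) and piperidin-2-yl (a 2.2-fold higher number from compound 1 to compound 4 (0.34 log units; beyond the scatter)). Placing (piperidin-1-yl)methyl in place of piperidin-1-yl, two bonds along the chain from an aromatic nitrogen, moves the number further: an at least 14-fold lower number from compound 2 to compound 4 (1.15 log units; beyond the scatter). Compound 2 stands at a limit, not a number: the limit of > 100000 nM in this assay, at which 1 of the 4 values shown sits.

On these data alone, whether a piperidin-4-yl group on the same chain would read lower than piperidin-3-yl remains open. So does the effect of a longer chain carrying piperidin-3-yl.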